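Replacing the furan group beside the amine in compound 3

This account rests on a few compounds, and the source may have more. Where it says the series, first, only, none or still open, it means among the compounds named here.

Measured so far in a physicochemical assay for acid dissociation:
compound 1 `CC(C)Cc1ccc2c(NCCCNCc3ccco3)ccnc2c1` gives 9.47
compound 2 `c1ccc(CCc2ccc3c(NCCCNCc4ccco4)ccnc3c2)cc1` gives 9.47
compound 3 `COc1ccccc1Oc1ccc2c(NCCCNCc3ccco3)ccnc2c1` gives 9.28

Compound 3 has the lowest of the three numbers, but its neighbours sit within the scatter: a number 0.19 log units lower from compound 1 to compound 3 (within the scatter) and a number 0.19 log units lower from compound 2 to compound 3 (within the scatter). The step of no change at the digits printed from compound 1 to compound 2 (within the scatter) is likewise flat. All three changes touched the far end of the shared core, away from the amine.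

Compound 4 `COc1ccccc1Oc1ccc2c(NCCCNCc3cccc(OC)c3O)ccnc2c1` differs from compound 3 in a different place: 2-hydroxy-3-methoxyphenyl in place of furan-2-yl on a saturated chain carbon bound to an amine nitrogen. For the measured compounds named here, no measured step alters the group on this carbon, so the three steps offer no direct guide; they only show that the proton is given up at a similar ease across the series when distant groups change. With nothing pointing one way, the expectation for compound 4 is a number close to compound 3, with a wider range to reflect the uncertainty, and a step of a number 0.02 log units higher from compound 3 to compound 4 (within the scatter). Compound 4 is therefore estimated at 9.3, between 8.6 and 10.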

Compound 4, acid dissociation constant: 9.28
Compound 4: the middle estimate sits 0.02 log units above what was measured; the measured number falls inside the stated range.
By their numbers in this assay, from the lowest: compounds 3, 4, 1 and 2 (each within the scatter of the next).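

In this assay, the first change made on a saturated chain carbon bound to an amine nitrogen gives no change at the digits printed from compound 3 to compound 4 (within the scatter). The earlier steps shown here all lay at the far end of the shared core, so this adds a first reading from the amine end, and it is flat even though the swap is large: furan-2-yl, with 5 heavy atoms and no hydrogen-bond donor, gives way to 2-hydroxy-3-methoxyphenyl, with 9 heavy atoms and 1 hydrogen-bond donor. No evidence is available on why this step is flat.

The hydroxy and methoxy groups entered together, so a plain phenyl at this place would be needed to tell them apart. Going by these compounds, whether a carboxylic acid or a second amine on this ring would move the number also remains open.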